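This account rests on a few compounds, and the source may have more. Where it says the series, first, only, none or still open, it means among the compounds named here.

- Compound 1 `COc1ccc(CCCN2CCC(COCc3ccc(Cl)cc3)CC2)cc1`: 500 nM
- Compound 2 `COc1ccc(CCCN2CCC(COC(c3ccc(Br)cc3)c3ccc(Br)cc3)CC2)cc1`: 3200 nM
- Compound 3 `CCCCN1CCC(COC(c2ccccc2)c2ccccc2)CC1`: 14000 nM

In a functional assay on cells (T-cell line, Homo sapiens) for inhibition (on this read-out lower numbers stand for stronger inhibition and higher numbers for weaker inhibition), compound 3 gives 14000 nM, the highest number of the three and therefore the weakest inhibition so far. Compound 4 `C(#Cc1ccccc1)CN1CCC(COC(c2ccccc2)c2ccccc2)CC1` differs from it in one place: 2-phenylethynyl in place of propyl on a saturated chain carbon bound to an amine nitrogen in a ring. Put another way, a butyl group on the amine nitrogen gives way to 3-phenylprop-2-yn-1-yl.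

Within the data shown here, no two measured compounds differ in only one place, so no direct comparison shows what this kind of change does. Among the measured compounds shown here, the only guide is indirect. Compound 2, at 3200 nM, has an aromatic ring in the chain on the amine nitrogen, as does compound 1, at 500 nM. Compound 3 has none, although the three compounds also differ elsewhere. A drop beyond the scatter, toward stronger inhibition, therefore seems likely, and the expected step is a 4.7-fold lower number from compound 3 to compound 4 (0.67 log units; beyond the scatter). The estimated value for compound 4 is 3000 nM, with an expected range of 800 nM to 11000 nM.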

Compound 4, half-maximal inhibitory concentration: > 20000 nM
Compound 4 gave a limit, no number; the forecaster's own chance of this, stated with the estimate: 5%; at least 6.6-fold (0.82 log units) between middle value and limit.
By their numbers in this assay, from the lowest: compound 1; then compound 2; then compound 3. At a limit, above all of these: compound 4.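

In this assay compound 4 gives > 20000 nM, which is a limit and not a number, and it is the only compound shown that sits there: the limit of > 20000 nM in this assay, at which 1 of the 4 values shown sits. The comparison with its butyl-bearing partner gives an at least 1.4-fold higher number from compound 3 to compound 4 (0.15 log units; that floor lies within the scatter), so only a floor can be read, and that floor alone does not establish a change beyond the scatter. Even so, this first one-place comparison on the amine nitrogen shows that replacing butyl with 3-phenylprop-2-yn-1-yl, which adds an aromatic ring and a triple bond, brings no stronger inhibition on this core.

As far as these compounds go, how far compound 4 lies past its limit remains unknown. Also open, from the compounds shown here alone, is how a 3-phenylpropyl group, with a saturated chain in place of the triple bond, or a butyl chain ending in an amine or a carboxylic acid would behave on the same nitrogen.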